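Side-chain swap from compound 3 to compound 4

This account rests on a few compounds, and the source may have more. Where it says the series, first, only, none or still open, it means among the compounds named here.

- compound 1 `CN1C(=S)[C@@H](NC(=O)c2nc(Cc3ccccc3)n(C)n2)COc2ccccc21`: 2.5 nM
- compound 2 `CCCCCn1nc(C(=O)N[C@H]2COc3ccccc3N(C)C2=S)nc1Cc1ccccc1`: 805 nM
- compound 3 `CC(C)Cn1nc(C(=O)N[C@H]2COc3ccccc3N(C)C2=S)nc1Cc1ccccc1`: 1230 nM

All three values come from a functional assay on HT-29 cells (Homo sapiens) for inhibition, read by luminescence and CellTiter-Glo, with a stated time of 24 h; a lower number here means that less compound is needed, a higher number that more compound is needed for the effect. Compound 3 lies far from the low value, with a 490-fold higher number from compound 1 to compound 3 (2.69 log units; beyond the scatter), and level with its nearest neighbour, with a 1.5-fold higher number from compound 2 to compound 3 (0.18 log units; within the scatter). Butyl in place of hydrogen gave a 320-fold higher number from compound 1 to compound 2 (2.51 log units; beyond the scatter).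

Compound 4 `CN1C(=S)[C@@H](NC(=O)c2nc(Cc3ccccc3)n(CCCO)n2)COc2ccccc21` carries 2-hydroxyethyl in place of isopropyl on a saturated chain carbon bound to an aromatic nitrogen. Among the compounds with values here, no measured compound carries this group, so the guidance is indirect. A moderate step to a lower number is expected, well short of the large measured steps. The expected change is a 4.1-fold lower number from compound 3 to compound 4 (0.61 log units; beyond the scatter). Compound 4 is estimated at 300 nM, within a range of 40 nM to 1500 nM.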

Compound 4, half-maximal effective concentration: 209 nM
The estimate for compound 4 lay 1.4-fold (0.16 log units) above the measured number; low and high end bracket the measured number.
By their numbers in this assay, from the lowest: compound 1; then compound 4; then compounds 2 and 3 (each within the scatter of the next).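

On this saturated chain carbon bound to an aromatic nitrogen, the chain end matters: there is a 5.9-fold lower number from compound 3 to compound 4 (0.77 log units; beyond the scatter) with the 2-hydroxyethyl group, and a 3.9-fold lower number from compound 2 to compound 4 (0.59 log units; beyond the scatter) when hydroxy replaces ethyl. Only part of the gap closes, since there remains an 84-fold higher number from compound 1 to compound 4 (1.92 log units; beyond the scatter) in this series. No measured evidence on the cause of these steps is available.

Open, from the compounds shown here alone, is whether an amine or a carboxylic acid at the chain end would narrow the remaining gap to compound 1. A longer hydroxy-bearing chain also remains to be placed against compound 4.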